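From Phenethyl Amide to Benzyl Urea at the Chemokine Receptor

The source may hold more compounds than are shown below. What is called first, only, known or untested is meant among the compounds shown, and "the series" means these compounds.

Compound 1, `CC(C)C(NS(=O)(=O)Cc1ccccc1)C(=O)N1CCC(c2ccc(Cl)cc2)CC1`, gives 303 nM in an assay on THP-1 cells for displacement of a labelled ligand from C-C chemokine receptor type 1 (Homo sapiens); on this read-out higher numbers stand for weaker inhibition and lower numbers for stronger inhibition.
Compound 2, `CC[C@@H](NC(=O)c1ccccc1)C(=O)N1CCC(c2ccc(Cl)cc2)CC1`, gives 121 nM in this assay.
Compound 3, `CC(C)[C@@H](NC(=O)CCc1ccc(F)cc1)C(=O)N1CCC(c2ccc(Cl)cc2)CC1`, gives 70 nM in this assay.

Of the compounds shown here, three sharing the same core have been measured. Compound 3 has the lowest number of the three. Its nearest neighbour is compound 2, whose value lies within the usual scatter of compound 3, so the two cannot be told apart on these data. Compound 1 sits furthest away, beyond the scatter, so compound 1 is a weaker inhibitor than compound 3.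

Compound 4, `CC(C)[C@@H](NC(=O)NCc1ccccc1)C(=O)N1CCC(c2ccc(Cl)cc2)CC1`, is not yet measured. It differs from compound 3 in one place: benzylamino in place of 2-(4-fluorophenyl)ethyl on a carbonyl carbon. The carbonyl and its amide-type nitrogen stay; the group on the other side of the carbonyl is changed.

Within the data shown here, no measured pair shows this kind of exchange, so no step can be read off for it. The three measured values span a modest range, and nothing in them points to a large move in either direction. The step from compound 3 to compound 4 is therefore expected to be small, at most a mild weakening, a 1.4-fold higher number from compound 3 to compound 4 (0.15 log units; within the scatter), and may not exceed the scatter. For compound 4 the estimate in this assay is 100 nM, with a range from 35 nM to 300 nM.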

Compound 4, half-maximal inhibitory concentration: 180 nM
The estimate for compound 4 lay 1.8-fold (0.26 log units) below the measured number, within the range that was stated.
By their numbers in this assay, from the lowest: compounds 3, 2, 4 and 1 (each within the scatter of the next, the first and the last beyond it).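

In this assay, among these compounds, the exchange on the carbonyl carbon gives the first step that can be read between two compounds differing in one place: benzylamino in place of 2-(4-fluorophenyl)ethyl yields a 2.6-fold higher number from compound 3 to compound 4 (0.41 log units; beyond the scatter) and so a modest weakening that lies beyond the usual scatter. This position, with the carbonyl and its amide-type nitrogen kept, therefore responds to the exchange, even though both groups carry one six-membered aromatic ring of carbon only and the entering group brings one hydrogen-bond donor where the leaving group has none. Nothing available accounts for the rise, and the step stands here as a measured difference only.

The exchange removes the fluorine and introduces the nitrogen in a single move, so the compounds shown cannot separate what each of these contributes to the step. Going by these compounds, it remains open how a 2-phenylethyl group without fluorine or a benzyloxy group, with oxygen in place of the nitrogen, would read on the same carbonyl carbon.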